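Replacing a ring with a chain on a TRPV1 antagonist

The compounds below may be only part of what the source reports. "The series", "measured", "known", "first", "only" and "open" are said of these compounds alone.

Compound 1 `CCC1CCN(c2cc(C(F)(F)F)ccc2CNC(=O)C(C)c2ccc(NS(C)(=O)=O)c(F)c2)CC1` is the starting point. In an assay on CHO cells for antagonist activity at transient receptor potential cation channel subfamily V member 1 (Homo sapiens), read by FLIPR (a higher number here means a weaker inhibitor, a lower number a stronger inhibitor), compound 1 gives 0.7 nM, level with compound 3 `Cc1ccc(N2CCN(c3cc(C(F)(F)F)ccc3CNC(=O)C(C)c3ccc(NS(C)(=O)=O)c(F)c3)CC2)cc1` and together the lowest of the three numbers; compound 3 gives 0.7 nM. Compound 2 `CC(C(=O)NCc1ccc(C(F)(F)F)cc1N1CCN(c2ccccc2)CC1)c1ccc(NS(C)(=O)=O)c(F)c1` gives 2 nM, the highest of the three. The two measured steps are both modest: a 2.9-fold higher number from compound 1 to compound 2 (0.46 log units; beyond the scatter) and a 2.9-fold lower number from compound 2 to compound 3 (0.46 log units; beyond the scatter).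

Compound 4 `CC(C)CCSc1cc(C(F)(F)F)ccc1CNC(=O)C(C)c1ccc(NS(C)(=O)=O)c(F)c1` differs from compound 1 in one place: isopentylsulfanyl in place of 4-ethylpiperidin-1-yl on an aromatic carbon. Going by the values given here, nothing measured so far swaps the ring for an open chain, so the two steps bear on it only loosely. They show that changing the group at this position moves the number by a modest amount in either direction. Some loss is expected from the step from compound 1 to compound 4, since the change is larger than a single methyl; the expected step is a 2.9-fold higher number from compound 1 to compound 4 (0.46 log units; beyond the scatter). Compound 4 is therefore estimated at 2 nM, with a range from 0.5 nM to 8 nM.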

Compound 4, inhibition constant: 1.4 nM
For compound 4 the middle estimate is 1.4-fold (0.15 log units) above the measured one, and the stated range covers the measured number.
By their numbers in this assay, from the lowest: compounds 1, 3, 4 and 2 (each within the scatter of the next, the first and the last beyond it).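

The result shows that a ring is not needed at this position to keep the number low in this assay. Replacing 4-ethylpiperidin-1-yl, a six-membered ring containing nitrogen, with isopentylsulfanyl, an open chain containing sulfur, gives a 2.0-fold higher number from compound 1 to compound 4 (0.30 log units; within the scatter), and replacing 4-phenylpiperazin-1-yl with the same chain gives a 1.4-fold lower number from compound 2 to compound 4 (0.15 log units; within the scatter), so across these two swaps the open chain reads the same as either ring. Nothing available explains why the chain is accepted here.

This change removes the ring and brings in sulfur at the same time, so the compounds shown cannot separate those two parts of the swap. Going by these compounds, how an isopentylamino or isopentyloxy chain, or a shorter ethylsulfanyl chain, would read at this position stays open.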